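Chloro to Methyl: Expecting Little Change in Cytotoxicity

The compounds below may be only part of what the source reports. "The series", "measured", "known", "first", "only" and "open" are said of these compounds alone.

Three compounds have been measured in a functional assay on HeLa cells (Homo sapiens) for cytotoxicity, read by sulforhodamine B assay, with a stated time of 48 h; on this read-out lower numbers stand for stronger inhibition and higher numbers for weaker inhibition:

compound 1 `COc1ccc(/C=C/C(=O)/C=C/C2=C(C)CCCC2(C)C)cc1` gives 15700 nM
compound 2 `CC1=C(/C=C/C(=O)/C=C/c2ccc([N+](=O)[O-])cc2)C(C)(C)CCC1` gives 28700 nM
compound 3 `CC1=C(/C=C/C(=O)/C=C/c2ccccc2Cl)C(C)(C)CCC1` gives 21800 nM

Compound 3 stands second highest of the three numbers; its nearest neighbour is compound 2, its furthest compound 1, and both gaps lie within the scatter, so the three compounds cannot be ranked against each other on these data. Among the compounds with values here, the single one-place step that has been measured, a 1.8-fold higher number from compound 1 to compound 2 (0.26 log units; within the scatter), also stayed within the scatter.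

Compound 4 `CC1=C(/C=C/C(=O)/C=C/c2ccccc2C)C(C)(C)CCC1` differs from compound 3 by methyl in place of chloro on an aromatic carbon. Within the data shown here, no measured step exchanges chloro for methyl, so the only guide is that the one exchange on the same aromatic ring, from methoxy to nitro, moved the number by no more than the scatter. Compound 4 is therefore expected to sit close to compound 3, with a 1.0-fold higher number from compound 3 to compound 4 (0.00 log units; within the scatter) showing no step beyond the scatter. The estimate for compound 4 in this assay is 22000 nM, with a range from 10000 nM to 48000 nM.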

Compound 4, half-maximal inhibitory concentration: > 100000 nM
Compound 4: a limit, no number (the forecaster's own chance of this, stated with the estimate: 10%); middle value at least 4.5-fold (0.65 log units) away from the limit.
By their numbers in this assay, from the lowest: compounds 1, 3 and 2 (each within the scatter of the next). At a limit, above all of these: compound 4.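

In this assay compound 4 gives > 100000 nM, which is a limit of the assay and not a number: the limit of > 100000 nM in this assay, at which 1 of the 4 values shown sits.

Within the data shown here, the exchange of one heavy atom, 2-chlorophenyl to 2-methylphenyl, gives an at least 4.5-fold higher number from compound 3 to compound 4 (0.66 log units; beyond the scatter), the only one-place step here to go beyond the scatter. The earlier step on an aromatic ring, a 1.8-fold higher number from compound 1 to compound 2 (0.26 log units; within the scatter), gave no sign that so small a change, on an aromatic carbon ortho to a large group, could separate two compounds in this way.

The compounds shown do not tell whether this result belongs to methyl in particular or would also follow from another group at this place, such as fluoro, bromo, ethyl or an amine. They give no cause for the step, and with only a limit for compound 4, its full size stays unknown.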